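Adding an Ester to a Weak Mannosidase Inhibitor

A few compounds are considered here, and "the series" means these few. Any claim that something is new, unique, unknown or untested is made for them only; others in the source may bear on it.

Compound 1 `Cc1cc2c(c(=O)[nH]1)C(=O)O/C2=C\c1ccc(CO)n1-c1ccccc1`: 61400 nM
Compound 2 `OC[C@@H]1N[C@@H](c2ccc(O)cc2)[C@H](O)[C@H]1O`: 28000 nM
Compound 3 `CC(C)c1ccc(/C=C2\C(=O)Nc3cc(Cl)ccc32)cc1`: 28000 nM

Of the compounds shown here, three have been measured in an assay on isolated protein for inhibition of alpha-mannosidase (Canavalia ensiformis), read by spectrophotometry, with a stated time of 10 min; a lower number here means a stronger inhibitor, a higher number a weaker inhibitor. Compound 1 gives 61400 nM, the highest of the three numbers and therefore the weakest inhibitor of the set; compound 2 with 28000 nM and compound 3 with 28000 nM both sit beyond the scatter from it. Compound 4 `CCOC(=O)c1ccc(-n2c(/C=C3\OC(=O)c4c3cc(C)[nH]c4=O)ccc2CO)cc1` has not yet been measured. It differs from compound 1 in a single place: ethoxycarbonyl in place of hydrogen on an aromatic carbon, on an aromatic carbon of a six-membered aromatic ring of carbon only, para to a large group. Among the compounds with values here, no measured pair shows this change, so its effect cannot be read from the data. Compound 4 is expected to remain close to compound 1, with a step of a 1.2-fold lower number from compound 1 to compound 4 (0.09 log units; within the scatter) that stays within the scatter. The estimate for compound 4 is 50000 nM, between 15000 nM and 150000 nM.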

Compound 4, half-maximal inhibitory concentration: 41200 nM
Estimate against measurement, compound 4: 1.2-fold (0.08 log units) above; the measured number falls inside the stated range.
By their numbers in this assay, from the lowest: compounds 2, 3, 4 and 1 (each within the scatter of the next, the first and the last beyond it).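

In this assay, ethoxycarbonyl in place of hydrogen on an aromatic carbon, para to a large group, gives a 1.5-fold lower number from compound 1 to compound 4 (0.17 log units; within the scatter) and stays within the scatter. This position can therefore carry a group of 5 heavy atoms, with no measurable difference between the two compounds. No available evidence explains this result.

As far as these compounds go, whether a carboxylic acid or an amine at this place would move the number beyond the scatter remains open. The same holds for a longer chain on the ester.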